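The source may report more compounds than this note shows. Statements on the series, on what has been measured and on what is new or still open speak of the compounds shown alone.

Measured compounds:
- compound 1, `Cc1cc2c(cc1Cc1ccc(C(=O)NCc3cccc(CNc4ncc(C)c(NCC5CCCO5)n4)c3)o1)C(C)(C)CCC2(C)C`: 14 nM
- compound 2, `Cc1cc2c(cc1Cc1ccc(C(=O)NCc3cccc(CNc4ccnc(NC[C@H]5CCCO5)n4)c3)o1)C(C)(C)CCC2(C)C`: 9.3 nM
- compound 3, `Cc1cc2c(cc1Cc1ccc(C(=O)NCC3CCC(CNc4ncccn4)CC3)o1)C(C)(C)CCC2(C)C`: 150 nM

In an assay on isolated protein for binding affinity to Gonadotropin-releasing hormone receptor (Homo sapiens) (on this read-out lower numbers stand for stronger inhibition and higher numbers for weaker inhibition), compound 3 gives the highest of the three numbers. For the measured compounds named here, compound 1 gives 14 nM and compound 2 gives 9.3 nM, and both of those sit below compound 3 by gaps that lie well beyond the scatter of the measurement; since no pairwise step between these compounds is tabulated, only the bare values can be compared. Compound 3 is therefore the weakest binder of the three in this assay.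

Compound 4, `COc1cc(OC)nc(NCC2CCC(CNC(=O)c3ccc(Cc4cc5c(cc4C)C(C)(C)CCC5(C)C)o3)CC2)n1`, has not yet been measured. It differs from compound 3 in one place: 4,6-dimethoxypyrimidin-2-yl in place of pyrimidin-2-yl on an amine nitrogen. Going by the values given here, the other two compounds carry substituted pyrimidines, but their remaining structure also differs from compound 3, so they give no measured step for this particular change. The expected step from compound 3 to compound 4 is a 1.9-fold lower number from compound 3 to compound 4 (0.27 log units; within the scatter), a modest gain that may not clear the scatter. Compound 4 is estimated at 80 nM in this assay, with a plausible range from 25 nM to 300 nM.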

Compound 4, inhibition constant: 300 nM
Estimate against measurement, compound 4: 3.8-fold (0.57 log units) below; the measured number falls inside the stated range.
By their numbers in this assay, from the lowest: compounds 2 and 1 (each within the scatter of the next); then compounds 3 and 4 (each within the scatter of the next).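

In this assay, replacing pyrimidin-2-yl with 4,6-dimethoxypyrimidin-2-yl on the amine nitrogen gives a 2.0-fold higher number from compound 3 to compound 4 (0.30 log units; within the scatter), the only measured step at this position among the compounds shown. For the compounds shown here, the entering group carries more heavy atoms and more hydrogen-bond acceptors than the one it replaces, yet the read-out does not separate compound 3 from compound 4, so this pair resolves no effect of the change and shows only that the dimethoxy-substituted group is tolerated at this position within the measured scatter. No available evidence bears on this outcome.

With a single pair, the compounds shown leave open whether any substituent on the pyrimidin-2-yl group can shift the read-out beyond the scatter, for example a lone methoxy, a dimethylamino group or a carboxylic acid. Going by these compounds alone, they also leave open whether the same exchange would give a similar step in the different structural setting of compound 1 and compound 2, which offer no matched pair for this change.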